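A few compounds are considered here, and "the series" means these few. Any claim that something is new, unique, unknown or untested is made for them only; others in the source may bear on it.

The measured compounds:

Compound 1, `OC[C@H]1O[C@@H](n2cnc3c(NCc4ccc(F)cc4)ncnc32)[C@H](O)[C@@H]1O`: 1200 nM
Compound 2, `Cc1cccc(CNc2ncnc3c2ncn3[C@@H]2O[C@H](CO)[C@@H](O)[C@H]2O)c1`: 6400 nM
Compound 3, `COc1cc(O)cc(OC)c1CNc1ncnc2c1ncn2[C@@H]1O[C@H](CO)[C@@H](O)[C@H]1O`: "not determined" (no result reported)

In a functional assay on HL-60 cells (Homo sapiens) for antiproliferative activity, with a stated time of 72 h (on this read-out lower numbers stand for stronger inhibition and higher numbers for weaker inhibition), compound 1 gives 1200 nM and compound 2 gives 6400 nM. Among the two compounds with a number, compound 2 stands at the highest, that is the weakest, and the single measured step is a 5.3-fold higher number from compound 1 to compound 2 (0.73 log units; beyond the scatter). Compound 3 carries no result and so adds nothing to the comparison.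

Compound 4, `Cc1cccc(CNc2ncnc3c2ncn3[C@@H]2O[C@H](CO)[C@@H](O)[C@H]2O)c1O`, differs from compound 2 in one place: hydroxy in place of hydrogen on an aromatic carbon. Going by the values given here, the only measured step swaps one whole aromatic group for another; it does not concern a hydroxy entering an aromatic carbon and therefore gives no guide. Among the compounds with values here, with no step bearing on this change, the expectation for compound 4 is a number within the scatter of compound 2, with no direction favoured. The change from compound 2 to compound 4 is expected to be a 1.3-fold lower number from compound 2 to compound 4 (0.11 log units; within the scatter). Compound 4 is therefore estimated at 5000 nM, with a range from 1500 nM to 20000 nM.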

Compound 4, half-maximal inhibitory concentration: 15000 nM
Beside the measured number, compound 4's estimate is 3.0-fold (0.48 log units) below it; the range from low to high includes it.
By their numbers in this assay, from the lowest: compound 1; then compound 2; then compound 4.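

In this assay, putting hydroxy in place of hydrogen on an aromatic carbon gives a 2.3-fold higher number from compound 2 to compound 4 (0.37 log units; beyond the scatter) and so costs some inhibition at this position, ortho to a large group and ortho to a methyl group. Exchanging the whole group, 2-hydroxy-3-methylphenyl in place of 4-fluorophenyl, gives a 13-fold higher number from compound 1 to compound 4 (1.10 log units; beyond the scatter) and spans the widest gap among the compounds with a number. Nothing available here explains this loss of inhibition.

This single example leaves open whether the loss belongs to the hydroxy itself or to the place it occupies. An amine or a chlorine on the same aromatic carbon, or a hydroxy on the same carbon with no methyl group on the ring, would help to separate these two readings.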